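The source may hold more compounds than are shown below. What is called first, only, known or untested is meant among the compounds shown, and "the series" means these compounds.

Compound 1 `FC(F)(F)c1ccc(/C=C\c2cc3ccccc3nc2Cl)cc1` gives 4220 nM in a functional assay on HeLa cells (Homo sapiens) for antiproliferative activity, read by sulforhodamine B assay, with a stated time of 72 h; on this read-out higher numbers stand for weaker inhibition and lower numbers for stronger inhibition. Compound 2 `FC(F)(F)c1ccc(/C=C\c2cc3ccc(Cl)cc3nc2Cl)cc1` carries the change chloro in place of hydrogen on an aromatic carbon on the core of compound 1. In this assay compound 2 gives 12600 nM, so the step is a 3.0-fold higher number from compound 1 to compound 2 (0.48 log units; beyond the scatter). Compound 3 `FC(F)(F)c1cc(/C=C\c2cc3ccccc3nc2Cl)cc(C(F)(F)F)c1` gives 6780 nM in this assay; the difference between the core of compound 3 and the core of compound 1 is not broken down here, and the two values lie within the scatter of each other, as do those of compound 3 and compound 2.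

Compound 4 `FC(F)(F)c1cc(/C=C\c2cc3ccc(Cl)cc3nc2Cl)cc(C(F)(F)F)c1` is the unmeasured member; relative to compound 3 it carries the change (chloro in place of hydrogen on an aromatic carbon), the same change as that from compound 1 to compound 2, at a place described in the same words. Within the data shown here, from compound 3 to compound 4 the step is expected to be a 2.9-fold higher number from compound 3 to compound 4 (0.47 log units; beyond the scatter), set beside the earlier one, which rests on the only prior instance, the step of a 3.0-fold higher number from compound 1 to compound 2 (0.48 log units; beyond the scatter), a single example that may not carry over in full. In this assay compound 4 is therefore expected to give about 20000 nM, likely between 9000 nM and 45000 nM.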

Compound 4, half-maximal inhibitory concentration: 41400 nM
Compound 4: middle estimate off by 2.1-fold (0.32 log units), on the low side; the measured number falls inside the stated range.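

In this assay, chloro in place of hydrogen on an aromatic carbon again gives a weaker result, a 6.1-fold higher number from compound 3 to compound 4 (0.79 log units; beyond the scatter), so the direction of the step is the same on both cores shown. The two steps cannot be told apart in size: the same change on two cores in this assay, a 3.0-fold higher number (0.48 log units; beyond the scatter) from compound 1 to compound 2 and a 6.1-fold higher number (0.79 log units; beyond the scatter) from compound 3 to compound 4, 2.0-fold (0.31 log units) apart, within the scatter of two such steps. Among these compounds, the change therefore carries over between these two cores in direction and, within the scatter, in size, but this rests on only two pairs in one cell assay and does not show that it would hold on a further core, nor why the number rises.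

The compounds shown leave open whether another group at this place, such as fluoro, methoxy, an amine or a carboxylic acid, would shift the number in the same way as chloro. Also open, from the compounds shown here alone, is how the step behaves on a core carrying a nitrile or a methoxy group in place of trifluoromethyl.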